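Chain shortening at selenium in two related cores

The source may report more compounds than this note shows. Statements on the series, on what has been measured and on what is new or still open speak of the compounds shown alone.

Compound 1 `CCCCC[Se]c1nc(NCc2ccccc2)c2ccccc2n1` gives 70900 nM in an ADME assay on 184B5 cells (Homo sapiens) for cytotoxicity, read by MTT assay, with a stated time of 72 h; on this read-out lower numbers stand for stronger inhibition of growth and higher numbers for weaker inhibition of growth. Compound 3 `C[Se]c1nc(NCc2ccccc2)c2ccccc2n1` differs by hydrogen in place of butyl on a saturated chain carbon bound to a selenium atom and gives 3720 nM in this assay, a step of a 19-fold lower number from compound 1 to compound 3 (1.28 log units; beyond the scatter). Compound 2 `CCCCC[Se]c1nc(N)c2cccnc2n1` gives 10300 nM in this assay; the difference between the cores of compound 1 and compound 2 is not broken down here. Compound 4 `C[Se]c1nc(N)c2cccnc2n1` carries the same change relative to compound 2, namely (hydrogen in place of butyl on a saturated chain carbon bound to a selenium atom), the place being the same in both pairs. It has not been measured in this assay. Going by the values given here, since the change in the core of compound 1 produced a 19-fold lower number from compound 1 to compound 3 (1.28 log units; beyond the scatter), a step of similar size, an 11-fold lower number from compound 2 to compound 4 (1.06 log units; beyond the scatter), is expected from compound 2 to compound 4 in this assay, with a wider range because only one matched pair supports it. Compound 4 is estimated at 900 nM, between 200 nM and 4000 nM.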

Compound 4, concentration for 50% growth inhibition: 45500 nM
The estimate for compound 4 lay 51-fold (1.70 log units) below the measured number; the measured number lies above the stated range.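

The change from pentyl to methyl gives a 4.4-fold higher number from compound 2 to compound 4 (0.65 log units; beyond the scatter), so its effect in this assay does not carry from one core to the other, and even its direction differs: the same change on two cores in this assay, a 19-fold lower number (1.28 log units; beyond the scatter) from compound 1 to compound 3 and a 4.4-fold higher number (0.65 log units; beyond the scatter) from compound 2 to compound 4, 84-fold (1.93 log units) apart, beyond the scatter of two such steps

This shows that a step read on one core cannot be used to predict the step on the other in this series. Going by these compounds alone, it does not show what sets the difference, as the two cores differ in more than one place and each supplies only one matched pair.

Open, as far as these compounds go, is whether an ethyl or propyl chain would fall in line with the methyl and pentyl values on either core. Also open, from the compounds shown here alone, is whether the benzyl group of compound 1 or the rest of its core governs the direction of the step.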